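The source may hold more compounds than are shown below. What is called first, only, known or untested is meant among the compounds shown, and "the series" means these compounds.

The account follows compound 1 `ClCc1ccc(Cn2cnc3c(Cl)ncnc32)cc1` into compound 3 `Nc1nc(Cl)c2ncn(Cc3ccc(CCl)cc3)c2n1`. In a functional assay on PC-3 cells (Homo sapiens) for cytotoxicity, read by sulforhodamine B assay, with a stated time of 48 h (on this read-out higher numbers stand for lower toxicity in this test and lower numbers for higher toxicity in this test), compound 1 gives only a limit, > 100000 nM. On the numbers shown, compound 1 stands at the limit of > 100000 nM in this assay, at which 1 of the 2 values shown sits, so it has no number of its own. Within the data shown here, the other measured compound, compound 2 `ClCc1ccccc1Cn1cnc2c(Cl)nc(Cl)nc21`, differs from compound 1 in more than one place, and no single step joins them; in this assay compound 2 gives 5120 nM. The change from compound 1 to compound 3 is amino in place of hydrogen on an aromatic carbon. Among the measured compounds shown here, no measured step shows how this change behaves in this setting. The step from compound 1 to compound 3 is expected to be none beyond the scatter, in either direction, as an at least 1.2-fold lower number from compound 1 to compound 3 (0.09 log units; that floor lies within the scatter). For compound 3 the estimate is 80000 nM, within a range from 20000 nM to 300000 nM, with a fair chance that only a limit is reported again.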

Compound 3, concentration lethal to 50% of the cells: 70800 nM
The estimate for compound 3 lay 1.1-fold (0.05 log units) above the measured number; the measured number falls inside the stated range.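

In this assay, among these compounds, compound 3 gives 70800 nM, the first number of its own on the core of compound 1, with amino in place of hydrogen on an aromatic carbon between two ring nitrogen atoms. The step reads as an at least 1.4-fold lower number from compound 1 to compound 3 (0.14 log units; that floor lies within the scatter), so the change is shown only through a floor, and that floor does not separate the two compounds from the scatter. The true size of the step stays unknown because compound 1 rests on a limit of the assay: the limit of > 100000 nM in this assay, at which 1 of the 3 values shown sits.

The compounds shown leave open how a methylamino group, a dimethylamino group or a hydroxyl group would read at this same place. They also leave open whether amino in place of hydrogen would give a similar result on a different core.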